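Morpholine Amide in Place of Methylamide on a Urea Scaffold

The source may hold more compounds than are shown below. What is called first, only, known or untested is meant among the compounds shown, and "the series" means these compounds.

The measured compounds, in a functional assay on HT-29 cells (Homo sapiens) for inhibition, read by MTT assay, with a stated time of 120 h; on this read-out higher numbers stand for weaker inhibition and lower numbers for stronger inhibition:
- compound 1, `CNC(=O)/C(C)=C/c1ccc(NC(=O)Nc2ccc(Cl)c(C(F)(F)F)c2)cc1`, gives only a limit of this assay, > 50000 nM
- compound 2, `C/C(=C\C(=O)N1CC(C)OC(C)C1)c1ccc(NC(=O)Nc2ccc(Cl)c(C(F)(F)F)c2)cc1`, gives 26200 nM
- compound 3, `CNC(=O)/C=C(\C)c1ccc(NC(=O)Nc2ccc(Cl)c(C(F)(F)F)c2)cc1`, gives only a limit of this assay, > 50000 nM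

Compounds 1 and 3 share the same atoms joined differently; the difference between their cores is 2-(methylcarbamoyl)prop-1-en-1-yl in place of 1-methyl-2-(methylcarbamoyl)ethenyl on an aromatic carbon. Both sit at the limit, so the step that the two limits leave unreadable from compound 1 to compound 3 cannot be read, a point underlined by the limit of > 50000 nM in this assay, at which 2 of the 3 values shown sit.

Compound 2 differs from compound 3 by 2,6-dimethylmorpholin-4-yl in place of methylamino on a carbonyl carbon. This change brings the step of an at least 1.9-fold lower number from compound 3 to compound 2 (0.28 log units; that floor lies within the scatter), and since compound 3 sits at a limit, only a floor for that step is known.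

Compound 4, `C/C(=C\c1ccc(NC(=O)Nc2ccc(Cl)c(C(F)(F)F)c2)cc1)C(=O)N1CC(C)OC(C)C1`, has not yet been measured. It differs from compound 1 by 2,6-dimethylmorpholin-4-yl in place of methylamino on a carbonyl carbon. The place line reads word for word as for the change from compound 3 to compound 2, so this is the same change, now made on the core of compound 1. On that basis, a step of similar size is expected from compound 1 to compound 4, namely an at least 1.6-fold lower number from compound 1 to compound 4 (0.22 log units; that floor lies within the scatter), resting on the floor seen in an at least 1.9-fold lower number from compound 3 to compound 2 (0.28 log units; that floor lies within the scatter). Because compound 1 itself gives only the limit > 50000 nM, a fair chance remains that compound 4 also returns a limit. The expected value for compound 4 in this assay is 30000 nM, with a range from 12000 nM to 80000 nM.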

Compound 4, half-maximal inhibitory concentration: > 50000 nM
Compound 4: only a limit was reported; the forecaster's own chance of this, stated with the estimate: 40%; middle value at least 1.6-fold (0.22 log units) from the limit.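

In this assay compound 4 gives > 50000 nM, which is a limit of the assay and not a number. Compound 1 gives the same limit, so no step from compound 1 to compound 4 can be read, and this limit recurs among the compounds shown: the limit of > 50000 nM in this assay, at which 3 of the 4 values shown sit. From the compounds shown here alone, it stays open whether 2,6-dimethylmorpholin-4-yl in place of methylamino on a carbonyl carbon changes the read-out at all on the core of compound 1.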